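A few compounds are considered here, and "the series" means these few. Any claim that something is new, unique, unknown or untested is made for them only; others in the source may bear on it.

In a functional assay on the whole organism with Mus musculus as the target, in the maximal electroshock model (a lower number here means that less compound is needed, a higher number that more compound is needed for the effect), compound 1 `OC1CCN(c2ccc(-c3ccccc3)nn2)CC1` gives 86 mg/kg, while compound 2 `OC1CCN(c2ccc(-c3cc(Cl)ccc3Cl)nn2)CC1` gives 30 mg/kg. Compound 2 therefore has the lower of the two numbers, and the gap between them lies beyond the usual scatter. Compound 3 `OC1CCN(c2ccc(-c3cccc(Cl)c3)nn2)CC1` differs from compound 2 by a single change: hydrogen in place of chloro on an aromatic carbon, with hydrogen in place of chloro on an aromatic carbon. Within the data shown here, no measured pair yet shows what a single change of this kind does, so any forecast is uncertain. A small rise is expected, meaning somewhat more compound would be needed, probably within the scatter: a 1.5-fold higher number from compound 2 to compound 3 (0.18 log units; within the scatter). For compound 3, the estimated value is 45 mg/kg, with a range of 22 mg/kg to 95 mg/kg.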

Compound 3, dose for half-maximal effect: 45 mg/kg
Beside the measured number, compound 3's estimate shows no gap at the digits printed; low and high end bracket the measured number.
By their numbers in this assay, from the lowest: compounds 2, 3 and 1 (each within the scatter of the next, the first and the last beyond it).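

Removing the chloro group ortho to a large group and para to a chloro group gives a 1.5-fold higher number from compound 2 to compound 3 (0.18 log units; within the scatter) in this assay and stays within the scatter. Adding the chloro group that compound 3 keeps gives a 1.9-fold lower number from compound 1 to compound 3 (0.28 log units; within the scatter) and also stays within the scatter, so neither single chloro change can be read as a real shift on its own. Still open, as far as these compounds go, is whether another group at this position, such as methoxy or an amine, would move the number beyond the scatter. No measurement shown explains these steps.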